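Acetyl in place of hydrogen on the hydroxy terminus

The source may hold more compounds than are shown below. What is called first, only, known or untested is meant among the compounds shown, and "the series" means these compounds.

Compound 1 `CN(C)c1ncnc2c1ncn2COCCO`: a limit only, > 500 ug/mL.
Compound 2 `Nc1nc(Cl)c2ncn(COCCO)c2n1`: a limit only, > 1000 ug/mL.

Compound 2 stands at a limit of a functional assay on L1210 cells (Mus musculus) for inhibition (a higher number here means a weaker inhibitor, a lower number a stronger inhibitor), namely (the limit of > 1000 ug/mL in this assay, at which 1 of the 2 values shown sits). Compound 1 stands at a limit as well, (the limit of > 500 ug/mL in this assay, at which 1 of the 2 values shown sits). Neither compound yields a number, so compound 2 cannot be placed relative to compound 1 beyond the fact that both are too weak for this assay to resolve.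

Compound 3 `CC(=O)OCCOCn1cnc2c(Cl)nc(N)nc21` differs from compound 2 by acetyl in place of hydrogen on an oxygen on a saturated carbon. For the measured compounds named here, no measured pair shows this change, so the size of the step is not anchored by data. Given that compound 2 itself sits at > 1000 ug/mL, a limit, the step is expected to stay within the scatter, and the expected step of a number no higher from compound 2 to compound 3 (the limit leaves the size open) reflects that. Compound 3 is thus estimated at 1000 ug/mL, between 300 ug/mL and 3000 ug/mL, and is expected to be reported as a limit again.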

Compound 3, concentration for 50% inhibition: > 1000 ug/mL
Compound 3 was reported as a limit; the forecaster's own chance of this, stated with the estimate: 85%; the middle value lies on the limit itself.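

In this assay compound 3 gives > 1000 ug/mL, a limit. For the compounds shown here, compound 2 gives > 1000 ug/mL, also a limit, so no step between compound 2 and compound 3 can be read. The compounds shown leave open whether acetyl in place of hydrogen on this oxygen changes inhibition at all.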